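This account rests on a few compounds, and the source may have more. Where it says the series, first, only, none or still open, it means among the compounds named here.

Compound 1 `C=C1C(=O)[C@]23C[C@@]1(O)CC[C@H]2c1ccc(OS(=O)(=O)c2ccc(C)cc2)c(C)c1[C@@H]3Cn1cc(-c2ccccn2)nn1` gives 320 nM in a functional assay on MCF7 cells (Homo sapiens) for cytotoxicity, read by MTT assay, with a stated time of 4 days; a lower number here means a stronger inhibitor, a higher number a weaker inhibitor.
Compound 2 `C=C1C(=O)[C@]23C[C@@]1(O)CC[C@H]2c1ccc(OS(=O)(=O)c2ccc(C)cc2)c(C)c1[C@@H]3Cn1cc(-c2ccc(Br)cc2)nn1` gives 250 nM in this assay.
Compound 3 `C=C1C[C@]23C[C@@]1(O)CC[C@@H]2c1cccc(C)c1[C@@H]3Cn1cc(-c2ccc(Br)cc2)nn1` reaches only a limit of the assay, > 20000 nM in this assay.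

Compound 1 and compound 2 share one core and differ in a single group on the five-membered ring with three nitrogens: pyridin-2-yl in place of 4-bromophenyl on an aromatic carbon. The step this makes is a 1.3-fold higher number from compound 2 to compound 1 (0.11 log units; within the scatter), so the two values sit within the scatter of each other and no order between them can be read. Compound 3 is built on a different core from compound 2; the difference between the two cores is not broken down here, and for compound 3 the assay reports only a limit, with the limit of > 20000 nM in this assay, at which 1 of the 3 values shown sits.

Compound 4 `C=C1C[C@]23C[C@@]1(O)CC[C@@H]2c1cccc(C)c1[C@@H]3Cn1cc(-c2ccccn2)nn1` is the not yet measured partner of compound 3 on that second core. The change from compound 3 to compound 4 is pyridin-2-yl in place of 4-bromophenyl on an aromatic carbon, the same change as from compound 2 to compound 1, at a place described in the same words. On the first core this change stayed within the scatter, as a 1.3-fold higher number from compound 2 to compound 1 (0.11 log units; within the scatter) shows, so for compound 4 a step that the limit leaves unreadable from compound 3 to compound 4 is expected, resting on that earlier step and on compound 3 sitting at a limit. Compound 4 is therefore expected to give about 30000 nM in this assay, between 12000 nM and 80000 nM, most likely again as a limit rather than a number.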

Compound 4, half-maximal inhibitory concentration: > 20000 nM
Compound 4: a limit, no number; the forecaster's own chance of this, stated with the estimate: 80%; the middle value lies beyond the limit too.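

Compound 4 gives > 20000 nM in this assay, which is a limit of the assay and not a number. Compound 3 also sits at a limit, so no step from compound 3 to compound 4 can be read: the limit of > 20000 nM in this assay, at which 2 of the 4 values shown sit.

The compounds shown leave open whether pyridin-2-yl in place of 4-bromophenyl changes the activity at all on the core of compound 3.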